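A few compounds are considered here, and "the series" means these few. Any claim that something is new, unique, unknown or untested is made for them only; others in the source may bear on it.

Two compounds of this series carry a measured value in a functional assay on HCT-116 cells (Homo sapiens) for cytotoxicity, read by MTT assay, with a stated time of 72 h; a higher number here means a weaker inhibitor, a lower number a stronger inhibitor. Compound 1 `NS(=O)(=O)c1cc(-c2nnc(CN3CCN(c4ccc(Cl)cc4)CC3)o2)c(Cl)cc1SCc1ccccc1` gives 78000 nM in this assay. Compound 2 `NC(=O)c1cn(Cc2nnc(-c3cc(S(N)(=O)=O)c(SCc4ccccc4)cc3Cl)o2)nn1` gives 72000 nM in this assay, the lower of the two numbers, though compound 1 sits within the usual scatter of it, so no order between the two can be drawn. Compound 3 `NS(=O)(=O)c1cc(-c2nnc(/C=C/c3ccc(Br)cc3)o2)c(Cl)cc1SCc1ccccc1` has not yet been measured in this assay. It derives from compound 2 by one change: 2-(4-bromophenyl)ethenyl in place of (4-carbamoyl-1H-1,2,3-triazol-1-yl)methyl on an aromatic carbon. Among the measured compounds shown here, no step between measured compounds bears on this exchange directly; what the two measured values show is that compound 1 and compound 2, which differ at the same place on the shared core, gave numbers within scatter of each other. On that basis the step to compound 3 is expected to stay within the scatter, with no clear direction, and the estimated step is a 1.2-fold lower number from compound 2 to compound 3 (0.08 log units; within the scatter). For compound 3 the estimate in this assay is 60000 nM, with an expected range from 20000 nM to 150000 nM.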

Compound 3, half-maximal inhibitory concentration: 15000 nM
Compound 3: the middle estimate sits 4.0-fold (0.60 log units) above what was measured, outside the stated range (below it).
By their numbers in this assay, from the lowest: compound 3; then compounds 2 and 1 (each within the scatter of the next).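

In this assay, the place on an aromatic carbon of the five-membered aromatic ring with 2 nitrogen and 1 oxygen proves able to move the number: 2-(4-bromophenyl)ethenyl in place of (4-carbamoyl-1H-1,2,3-triazol-1-yl)methyl gives a 4.8-fold lower number from compound 2 to compound 3 (0.68 log units; beyond the scatter) and is a modest step, whereas compound 1 and compound 2 gave no order at this place. The step comes with no change in the count of heavy atoms, while the group that enters brings a six-membered aromatic ring of carbon only and bromine, and has no hydrogen-bond donors or acceptors against the 1 donor and 4 acceptors of the group that leaves. Nothing available explains the step and the result stands as an observation on these compounds only.

Compound 3 changes several features at once, so the ethenyl link, the bromine and the loss of the carbamoyl-triazole cannot be told apart. From the compounds shown here alone, whether the step belongs to any one of them remains open, and a 2-phenylethenyl group without bromine, a saturated two-carbon chain ending in 4-bromophenyl, or a carboxylic acid at this place would bear on that question.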